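Urea aryl swap: chloro replacing trifluoromethyl

This account rests on a few compounds, and the source may have more. Where it says the series, first, only, none or still open, it means among the compounds named here.

Compound 2 `COc1cc(-c2nn(-c3cccc(NC(=O)Nc4ccc(Cl)c(C(F)(F)F)c4)c3)cc2-c2ccncc2)ccc1Cl` gives 19100 nM in a functional assay on SK-MEL-28 cells (Homo sapiens) for inhibition, read by sulforhodamine B assay, with a stated time of 48 h; a lower number here means that less compound is tolerated, a higher number that more compound is tolerated. Compound 1 `COc1cc(-c2nn(-c3cccc(NC(=O)Nc4cccc(C(F)(F)F)c4)c3)cc2-c2ccncc2)ccc1Cl` gives 21100 nM in this assay; the two numbers sit within the scatter of each other, so compound 2 stands level with compound 1 and no order between them can be drawn from what has been measured. Compound 3 `COc1cc(-c2nn(-c3cccc(NC(=O)Nc4ccc(Cl)c(Cl)c4)c3)cc2-c2ccncc2)ccc1Cl` is not yet measured. The change from compound 2 to compound 3 is chloro in place of trifluoromethyl on an aromatic carbon. Going by the values given here, the only measured step on the same ring, a 1.1-fold lower number from compound 1 to compound 2 (0.04 log units; within the scatter), stayed within the scatter, but it concerns a different exchange and is only a loose guide here. Nothing measured in the series shows what removing the trifluoromethyl group does. The step to compound 3 is therefore expected to be a 1.0-fold higher number from compound 2 to compound 3 (0.02 log units; within the scatter), with no move beyond the scatter assumed. Compound 3 is estimated at 20000 nM in this assay, with a range from 8000 nM to 50000 nM.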

Compound 3, concentration lethal to 50% of the cells: > 50000 nM
Compound 3: a limit, no number (the forecaster's own chance of this, stated with the estimate: 5%); middle value at least 2.5-fold (0.39 log units) away from the limit.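

Chloro in place of trifluoromethyl is the first exchange in this series to leave the scatter in this assay, with an at least 2.6-fold higher number from compound 2 to compound 3 (0.41 log units; beyond the scatter). The group on this aromatic carbon therefore affects the read-out, which a 1.1-fold lower number from compound 1 to compound 2 (0.04 log units; within the scatter) could not show, as that step concerned a different exchange; the change of 3-(trifluoromethyl)phenyl to 3,4-dichlorophenyl gives an at least 2.3-fold higher number from compound 1 to compound 3 (0.37 log units; beyond the scatter). The value of compound 3 is a limit and not a number, so both new steps set only a lower bound on the size of the change: the limit of > 50000 nM in this assay, at which 1 of the 3 values shown sits.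

As far as these compounds go, how far compound 3 lies past its limit stays open. Also open is what a methyl, a nitrile or an amine on this carbon would do to the read-out, so the compounds shown do not settle whether the trifluoromethyl group itself is needed.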